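Carbonyl aryl variation and cytotoxicity in the shared core

The compounds below may be only part of what the source reports. "The series", "measured", "known", "first", "only" and "open" are said of these compounds alone.

Compound 3 `COc1cc(-c2nnc3n2NC(c2ccco2)C(C(=O)c2ccc(C(F)(F)F)cc2)S3)cc(OC)c1OC` stands lowest of the numbers shown: in a functional assay on A549 cells (Homo sapiens) for cytotoxicity, read by MTT assay, with a stated time of 48 h (on this read-out lower numbers stand for stronger inhibition and higher numbers for weaker inhibition), compound 3 gives 37200 nM. Compound 1 `COc1cc(-c2nnc3n2NC(c2ccco2)C(C(=O)c2ccc(F)c(F)c2)S3)cc(OC)c1OC` in this assay gives 93700 nM, and the step of a 2.5-fold lower number from compound 1 to compound 3 (0.40 log units; beyond the scatter) is modest. Compound 2 `COc1cc(-c2nnc3n2NC(c2ccco2)C(C(=O)c2ccc(C)cc2)S3)cc(OC)c1OC` sits at the limit of > 100000 nM in this assay, at which 1 of the 3 values shown sits; in this assay compound 2 gives > 100000 nM, a limit rather than a number. The step of an at least 2.6-fold lower number from compound 2 to compound 3 (0.42 log units; beyond the scatter) is therefore at least modest. Compound 4 `COc1cc(-c2nnc3n2NC(c2ccco2)C(C(=O)c2ccc(-c4ccccc4)cc2)S3)cc(OC)c1OC` differs from compound 3 by phenyl in place of trifluoromethyl on an aromatic carbon. Both measured steps alter the same aromatic ring on the carbonyl carbon and shift the numbers only modestly, so a step of similar size, direction uncertain, is expected in this assay: the expected step is a 1.2-fold lower number from compound 3 to compound 4 (0.09 log units; within the scatter). Compound 4 is estimated at 30000 nM, between 10000 nM and 95000 nM.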

Compound 4, half-maximal inhibitory concentration: > 100000 nM
Compound 4 ended at the assay's limit; the forecaster's own chance of this, stated with the estimate: 15%; middle value at least 3.3-fold (0.52 log units) away from the limit.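

In this assay, phenyl in place of trifluoromethyl on this aromatic carbon gives an at least 2.6-fold higher number from compound 3 to compound 4 (0.42 log units; beyond the scatter), so a second aromatic ring at this place, as in 4-phenylphenyl, does not keep the lower number seen with 4-(trifluoromethyl)phenyl. Measured against 3,4-difluorophenyl, the change gives only a floor, an at least 1.0-fold higher number from compound 1 to compound 4 (0.02 log units; that floor lies within the scatter), and no order can be claimed from it. Compound 2 and compound 4 each give a limit rather than a number, so the step between them cannot be read: the limit of > 100000 nM in this assay, at which 2 of the 4 values shown sit.

As far as these compounds go, whether an amine or a carboxylic acid at this place would give a number lower than that of compound 3 stays open. From the compounds shown here alone, how far compound 2 and compound 4 lie beyond the limit also stays open.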